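A few compounds are considered here, and "the series" means these few. Any claim that something is new, unique, unknown or untested is made for them only; others in the source may bear on it.

Measured in an ADME assay on microsomes from liver (Homo sapiens) for metabolic stability, read by LC-MS, with a stated time of 10 min; on this read-out higher numbers stand for a more stable compound and lower numbers for a less stable compound:
- compound 1 `CN(C[C@H]1Cc2c(cccc2N2CCN(C3COC3)CC2)CN1)[C@H]1CCCc2cccnc21`: 83.1%
- compound 2 `Cc1cnc(CN(C)C[C@H]2Cc3c(cccc3N3CCNCC3)CN2)c(C)c1`: "not determined" (no result reported)
- compound 3 `CN(C[C@H]1Cc2c(cccc2N2CCNC(C)(C)C2)CN1)[C@H]1CCCc2cccnc21`: 100%

Compound 1 holds the lower of the two numbers available, at 83.1%. Compound 2 offers no number for comparison.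

Compound 4 `CN(C[C@H]1Cc2c(cccc2N2CCN3CCC[C@@H]3C2)CN1)[C@H]1CCCc2cccnc21` keeps the core of compound 1 and changes one group on an aromatic carbon: a group of 9 heavy atoms (7 carbon, 2 nitrogen; one five-membered non-aromatic ring with 1 hetero atom, one six-membered non-aromatic ring with 2 hetero atoms) in place of a group of 10 heavy atoms (7 carbon, 2 nitrogen, 1 oxygen; one four-membered non-aromatic ring with 1 hetero atom, one six-membered non-aromatic ring with 2 hetero atoms), on an aromatic carbon. The 4-(oxetan-3-yl)piperazin-1-yl group leaves, and with it the four-membered non-aromatic ring. A five-membered non-aromatic ring comes in its place, while a six-membered non-aromatic ring with 2 hetero atoms is present on both sides.

Within the data shown here, only one measured step bears on this change: a number 16.9 percentage points higher from compound 1 to compound 3 (beyond the scatter). It starts from the same group at the same place, but the group that enters is a different one, so it is an indirect guide. A single step also establishes no pattern. An upward move in this assay is therefore expected, smaller than the step to compound 3. The expected step is a number 6.9 percentage points higher from compound 1 to compound 4 (within the scatter). For compound 4 the estimated value is 90%, with an expected range from 72% to 100%.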

Compound 4, percent of the compound remaining: 52.2%
Estimate against measurement, compound 4: 37.8 percentage points above, outside the stated range (below it).
By their numbers in this assay, from the lowest: compound 4; then compound 1; then compound 3.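

In this assay, the position on the aromatic carbon now proves able to move the read-out down as well as up: the group with a five-membered and a six-membered non-aromatic ring gives a number 30.9 percentage points lower from compound 1 to compound 4 (beyond the scatter) and also a number 47.8 percentage points lower from compound 3 to compound 4 (beyond the scatter). A six-membered non-aromatic ring with 2 hetero atoms is present in all three groups, so its presence alone does not hold the value, and heavy-atom count does not order the results either, since the entering group is smaller than 4-(oxetan-3-yl)piperazin-1-yl and larger than 3,3-dimethylpiperazin-1-yl yet gives the lowest number of the three. No measurement at hand accounts for the drop.

Open is whether the drop belongs to the five-membered ring itself or to the defined stereocentre of the entering group, as its mirror-image form does not appear among the compounds shown. Also open, going by these compounds, is how simpler groups at this place, such as morpholin-4-yl or 4-methylpiperazin-1-yl, would read on the same core.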